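Moving from 2,4-dihydroxybenzyl to 2,5-dihydroxybenzyl: working notes

The source may hold more compounds than are shown below. What is called first, only, known or untested is meant among the compounds shown, and "the series" means these compounds.

- compound 1 `Cc1cc(-c2c(F)cc3c(=O)c(Cc4cccc(O)c4)cn(C4CC4)c3c2F)cc(C)n1`: 2200 nM
- compound 2 `Cc1cc(-c2c(F)cc3c(=O)c(Cc4cccc(O)c4O)cn(C4CC4)c3c2F)cc(C)n1`: 880 nM
- compound 3 `Cc1cc(-c2c(F)cc3c(=O)c(Cc4ccc(O)cc4O)cn(C4CC4)c3c2F)cc(C)n1`: 210 nM

In a functional assay on P388 cells (Mus musculus) for cytotoxicity (on this read-out higher numbers stand for weaker inhibition and lower numbers for stronger inhibition), compound 3 has the lowest of the three numbers at 210 nM. Compound 4 `Cc1cc(-c2c(F)cc3c(=O)c(Cc4cc(O)ccc4O)cn(C4CC4)c3c2F)cc(C)n1` carries 2,5-dihydroxyphenyl in place of 2,4-dihydroxyphenyl on a saturated chain carbon bound to an aromatic carbon. For the measured compounds named here, the closest precedent is the modest exchange of one dihydroxyphenyl for another, a 4.2-fold lower number from compound 2 to compound 3 (0.62 log units; beyond the scatter). The large 10-fold lower number from compound 1 to compound 3 (1.02 log units; beyond the scatter) and the modest 2.5-fold lower number from compound 1 to compound 2 (0.40 log units; beyond the scatter) show how far the number moves within this short series. A modest rise in this assay is therefore expected, though compound 3 may keep its place only narrowly. The estimated change is a 2.4-fold higher number from compound 3 to compound 4 (0.38 log units; beyond the scatter). Compound 4 is expected at 500 nM, with an estimated range of 170 nM to 1500 nM.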

Compound 4, half-maximal inhibitory concentration: 360 nM
Compound 4: middle estimate off by 1.4-fold (0.14 log units), on the high side; the range from low to high includes it.
By their numbers in this assay, from the lowest: compounds 3 and 4 (each within the scatter of the next); then compound 2; then compound 1.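

In this assay, 2,5-dihydroxyphenyl in place of 2,4-dihydroxyphenyl gives a 1.7-fold higher number from compound 3 to compound 4 (0.23 log units; within the scatter), so this position does not separate these two hydroxy patterns. The gain over 2,3-dihydroxyphenyl is therefore not confined to 2,4-dihydroxyphenyl, with a 2.4-fold lower number from compound 2 to compound 4 (0.39 log units; beyond the scatter), and the same group also stands clear of the single hydroxy, with a 6.1-fold lower number from compound 1 to compound 4 (0.79 log units; beyond the scatter). Nothing available explains these differences.

Open, on these data alone, is whether either hydroxy of 2,5-dihydroxyphenyl can be exchanged for a methoxy or an amine while the number stays in the range of compound 3 and compound 4.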